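Removing One Methyl Group From a Weak Hexosaminidase Inhibitor

A few compounds are considered here, and "the series" means these few. Any claim that something is new, unique, unknown or untested is made for them only; others in the source may bear on it.

Compound 1, with the structure `CCc1nc(N)nc(N)c1-c1cc(C)cc(C)c1`, was tested in an assay for inhibition of beta-N-acetyl-D-hexosaminidase-A/B (Homo sapiens) (a higher number here means a weaker inhibitor, a lower number a stronger inhibitor), and in this assay compound 1 gives 47000 nM. For the measured compounds named here, its only measured companion is compound 2, built on the same core but carrying a differently substituted phenyl ring, `CCc1nc(N)nc(N)c1-c1ccccc1C`; in this assay compound 2 gives 43000 nM. Of these two numbers, that of compound 1 is the larger, but the gap between them lies within the usual scatter of repeated measurements, so the two compounds cannot be told apart on potency: both are weak inhibitors.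

The step to compound 3, `CCc1nc(N)nc(N)c1-c1cccc(C)c1`, is a small trimming of compound 1: hydrogen in place of methyl on an aromatic carbon, the methyl lost being one heavy atom. Going by the values given here, no measured pair in this set isolates that kind of change, so there is nothing here to say whether it helps, hurts or leaves the number alone. Given the closeness of compound 1 and compound 2, the expectation from compound 1 to compound 3 is a step of about a 1.1-fold higher number from compound 1 to compound 3 (0.04 log units; within the scatter), none beyond the scatter. Compound 3 is therefore estimated at 52000 nM, with a range from 20000 nM to 130000 nM.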

Compound 3, half-maximal inhibitory concentration: 34000 nM
Estimate against measurement, compound 3: 1.5-fold (0.18 log units) above; the measured number falls inside the stated range.
By their numbers in this assay, from the lowest: compounds 3, 2 and 1 (each within the scatter of the next).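

For the compounds shown here, replacing the methyl group of compound 1 with hydrogen gives the first measured reading of this kind of change, and in this assay it amounts to a 1.4-fold lower number from compound 1 to compound 3 (0.14 log units; within the scatter) and so cannot be told apart from no change at all. For this aromatic carbon, meta to a large group and meta to a methyl group, this means that the methyl group can be lost without any difference that the assay can resolve, and that compound 3 stays a weak inhibitor, as compound 1 is. The data offer nothing that would account for this outcome.

The compounds shown carry only methyl or hydrogen at this carbon, so what a larger or differently built group, such as an amine, a hydroxyl group or a carboxylic acid, would do here remains open. From the compounds shown here alone, it also remains open whether any replacement at this carbon can move the number beyond the scatter, in either direction, since a single step within the scatter cannot settle that.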